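This account rests on a few compounds, and the source may have more. Where it says the series, first, only, none or still open, it means among the compounds named here.

Of the compounds shown here, three measured so far share one core: a ring bearing an ethoxy group joined to a second aromatic ring. In an assay on COS-7 cells for inhibition of patatin-like phospholipase domain-containing protein 2 (Mus musculus) (on this read-out higher numbers stand for weaker inhibition and lower numbers for stronger inhibition), compound 1 `CCOC(=O)c1ccnc(-c2ccc(OCC)cc2)c1` gives 80000 nM, and compound 2 `CCOC(=O)c1cccc(-c2ccc(OCC)c([N+](=O)[O-])c2)c1`, which carries its ethyl ester elsewhere on the second ring and adds a nitro group, gives 200000 nM. Compound 3 `CCOc1ccc(-c2ccccc2)cc1` is the bare core with nothing on the second ring, and in this assay it reaches only > 200000 nM, which is a limit of the assay rather than a number. Compound 3 therefore stands at the weak end of what has been measured (the limit of > 200000 nM in this assay, at which 1 of the 3 values shown sits).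

Compound 4 `CCOc1ccc(-c2cccc(C(=O)N3CCCC3)c2)cc1` is the same core with one change: (pyrrolidin-1-yl)carbonyl in place of hydrogen on an aromatic carbon. Among the measured compounds shown here, no measured pair shows this exact step, so the expectation rests on compound 1 at 80000 nM and on compound 2 at 200000 nM, both of which carry a carbonyl-containing group on that ring and both of which sit inside the measurable range. The step from compound 3 to compound 4 is expected to move toward stronger inhibition by an at least 3.3-fold lower number from compound 3 to compound 4 (0.52 log units; beyond the scatter), beyond the usual scatter. Compound 4 is thus estimated at 60000 nM, with a range from 15000 nM to 200000 nM.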

Compound 4, half-maximal inhibitory concentration: 160000 nM
For compound 4 the middle estimate is 2.7-fold (0.43 log units) below the measured one, within the range that was stated.
By their numbers in this assay, from the lowest: compounds 1, 4 and 2 (each within the scatter of the next, the first and the last beyond it).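

In this assay, (pyrrolidin-1-yl)carbonyl in place of hydrogen on this aromatic carbon gives a step on the otherwise bare core, an at least 1.2-fold lower number from compound 3 to compound 4 (0.09 log units; that floor lies within the scatter), so the size of this step is fixed only as a floor, and that floor does not clear the usual scatter. What this adds is modest but real: with this single group on the second ring, compound 4 gives 160000 nM, a true number inside the measurable range, yet nothing here shows a gain beyond the scatter for this change. The other end of the step is a limit and not a number, and it belongs to compound 3: the limit of > 200000 nM in this assay, at which 1 of the 4 values shown sits.

As far as these compounds go, it remains open whether the carbonyl or the five-membered ring carries the change, which an open-chain amide such as a diethylamide or a plain carboxylic acid on this same carbon could help separate. Also open, from the compounds shown here alone, is how a basic amine or a longer chain at this place would read on the bare core, and whether any single group here can move the number clearly beyond the scatter.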